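The compounds below may be only part of what the source reports. "The series", "measured", "known", "first", "only" and "open" are said of these compounds alone.

Of the two compounds measured in a functional assay on HCC 2998 cells (Homo sapiens) for antiproliferative activity, read by sulforhodamine B assay, with a stated time of 48 h (on this read-out lower numbers stand for stronger inhibition of growth and higher numbers for weaker inhibition of growth), compound 2 `Nc1nn(C(=O)Nc2ccc(Cc3ccccc3)cc2)c2ccc(Cl)cc12` gives the lower number, at 238 nM, while compound 1 `Nc1nn(C(=O)Nc2ccc(Cc3ccccc3)cc2)c2ccccc12` gives 4270 nM. Going by the values given here, the only step between them, an 18-fold lower number from compound 1 to compound 2 (1.25 log units; beyond the scatter), is large and runs well beyond the scatter. Compound 3 `Nc1ccc2c(c1)c(N)nn2C(=O)Nc1ccc(Cc2ccccc2)cc1` is built from compound 2 by a single change: amino in place of chloro on an aromatic carbon. Among the compounds with values here, no measured pair shows an amino group at this place, so the one step that bears on the change is that from compound 1 to compound 2, in which the chloro that compound 3 now loses was the sole difference. Removing that chloro suggests the number should move back toward compound 1, though the incoming amino may hold part of the gain, so a rise of moderate size is expected, a 6.3-fold higher number from compound 2 to compound 3 (0.80 log units; beyond the scatter). Compound 3 is therefore estimated at 1500 nM, within a range from 400 nM to 6000 nM.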

Compound 3, concentration for 50% growth inhibition: 4170 nM
For compound 3 the middle estimate is 2.8-fold (0.44 log units) below the measured one; measured number inside the range.
By their numbers in this assay, from the lowest: compound 2; then compounds 3 and 1 (each within the scatter of the next).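

In this assay the amino group holds none of the gain that went with the chloro: the result is an 18-fold higher number from compound 2 to compound 3 (1.24 log units; beyond the scatter) and, against the unsubstituted compound, a 1.0-fold lower number from compound 1 to compound 3 (0.01 log units; within the scatter) so compound 1 and compound 3 lie within the scatter of each other. At this aromatic carbon, among these three compounds, the lower number therefore goes with chloro alone, while hydrogen and amino read alike, so replacing hydrogen does not by itself bring the gain. Nothing at hand explains why chloro and amino differ so widely here. The compounds shown leave open whether fluoro, bromo, methyl or methoxy at this place would keep the low number of compound 2. They also leave open whether the step seen with chloro would recur on compounds that differ elsewhere from the core of compound 1.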